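Methoxy substitution across two core types

The compounds below may be only part of what the source reports. "The series", "measured", "known", "first", "only" and "open" are said of these compounds alone.

Compound 1 `CC1(C)CCCN(CCCC2CCc3ccccc32)C1` and compound 3 `CC1(C)CCCN(CCCCC2CCCc3ccccc32)C1` share the dimethylpiperidine side, but the difference between the two cores is not broken down here. In an assay on cell membranes for binding affinity to Sigma non-opioid intracellular receptor 1 (Rattus norvegicus), read by radioligand binding (on this read-out higher numbers stand for weaker inhibition and lower numbers for stronger inhibition), compound 1 gives 6.9 nM, and compound 3 gives 0.69 nM, the lowest number of the three measured. Within the data shown here, compound 2 `COc1ccc2c(c1)CCC2CCCN1CCCC(C)(C)C1` differs from compound 1 by methoxy in place of hydrogen on an aromatic carbon, and in this assay compound 2 gives 4660 nM; the step of a 680-fold higher number from compound 1 to compound 2 (2.83 log units; beyond the scatter) is the only measured example of this change. Compound 4 `COc1ccc2c(c1)C(CCCCN1CCCC(C)(C)C1)CCC2` carries the same change on the core of compound 3, namely (methoxy in place of hydrogen on an aromatic carbon); in both cases the entering group sits meta to a fused ring and para to a fused ring, so this is the same change, not merely the same kind. The expectation rests on compound 1, whose step a 680-fold higher number from compound 1 to compound 2 (2.83 log units; beyond the scatter) was large, applied to the value of compound 3 0.69 nM. For compound 4 the step of a 580-fold higher number from compound 3 to compound 4 (2.76 log units; beyond the scatter) is expected, in the same direction as before. In this assay compound 4 is expected to give 400 nM, somewhere between 60 nM and 2500 nM, because the earlier step of a 680-fold higher number from compound 1 to compound 2 (2.83 log units; beyond the scatter) lies far beyond the scatter.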

Compound 4, half-maximal inhibitory concentration: 25.6 nM
Estimate against measurement, compound 4: 16-fold (1.19 log units) above; the whole stated range lies above it.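

In this assay, methoxy in place of hydrogen on an aromatic carbon again gives a large step in the same direction on the second core, a 37-fold higher number from compound 3 to compound 4 (1.57 log units; beyond the scatter). The direction of the change carries over from one core to the other, but its size does not: the same change on two cores in this assay, a 680-fold higher number (2.83 log units; beyond the scatter) from compound 1 to compound 2 and a 37-fold higher number (1.57 log units; beyond the scatter) from compound 3 to compound 4, 18-fold (1.26 log units) apart, beyond the scatter of two such steps So a step measured on one core gives the sign of the step on the other in these two pairs, but not a usable size, and two pairs set no rule for further cores; they also do not show which difference between the cores goes with the difference in step size.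

Open, as far as these compounds go, is whether a hydroxy group or a fluorine atom on the same aromatic carbon gives a step of similar size, and what methoxy does on another carbon of that aromatic ring. Also open, from the compounds shown here alone, is whether a longer chain between the core and the dimethylpiperidine side alters the size of the methoxy step.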